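Two Measured Compounds Point Toward a Third

The source may report more compounds than this note shows. Statements on the series, on what has been measured and on what is new or still open speak of the compounds shown alone.

Compound 1 `O=C(COc1cccc2ccccc12)N/N=C/c1ccc(Cl)cc1` and compound 2 `O=C(COc1cccc2ccccc12)N/N=C/c1cccc(Br)c1` share the same core and differ only in the halogenated phenyl ring on the carbon with a double bond to nitrogen. In an ADME assay on HEL cells (Homo sapiens) for cytotoxicity (a lower number here means that less compound is tolerated, a higher number that more compound is tolerated), compound 1 gives 100 ug/mL, and compound 2 gives 48.6 ug/mL. The step of a 2.1-fold lower number from compound 1 to compound 2 (0.31 log units; beyond the scatter) separates them, so compound 2 stands at the lower of the two numbers, meaning less of it is tolerated than of compound 1.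

Compound 3 `O=C(COc1cccc2ccccc12)N/N=C/c1ccccc1Cl` has not yet been measured. The change from compound 2 is 2-chlorophenyl in place of 3-bromophenyl on a carbon with a double bond to nitrogen. Among the compounds with values here, the only measured step that bears on it, a 2.1-fold lower number from compound 1 to compound 2 (0.31 log units; beyond the scatter), was a modest one, and it also exchanged the halogen and its place on this same ring. Within the data shown here, no measured compound carries a 2-chlorophenyl, so the step to compound 3 in this assay is expected to be small, probably within the scatter, and if anything to move back toward the number of compound 1, because compound 1 with its chlorine gives 100 ug/mL. Compound 3 is therefore expected to give about 70 ug/mL, between 35 ug/mL and 140 ug/mL, a step of a 1.4-fold higher number from compound 2 to compound 3 (0.16 log units; within the scatter) that is estimated rather than known.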

Compound 3, half-maximal cytotoxic concentration: 62.7 ug/mL
Beside the measured number, compound 3's estimate is 1.1-fold (0.05 log units) above it, and the stated range covers the measured number.
By their numbers in this assay, from the lowest: compounds 2, 3 and 1 (each within the scatter of the next, the first and the last beyond it).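

In this assay, within the data shown here, this result gives the first comparison on a carbon with a double bond to nitrogen in which the halogen stays chlorine and only its place on the phenyl ring differs: the step of a 1.6-fold lower number from compound 1 to compound 3 (0.20 log units; within the scatter) lies within the scatter, so 2-chlorophenyl and 4-chlorophenyl cannot be told apart here. The step of a 1.3-fold higher number from compound 2 to compound 3 (0.11 log units; within the scatter) also lies within the scatter, so compound 3 cannot be told apart from compound 2 either, even though compound 1 and compound 2 lie beyond the scatter of each other. Across these three compounds, exchanging one halogenated phenyl for another moves the number only modestly, and no measurement available here bears on why the numbers fall where they do.

As far as these compounds go, it remains open whether bromine and chlorine differ at all when they sit at the same place on the ring, which a pair such as 3-chlorophenyl and 3-bromophenyl would show. Also open, from the compounds shown here alone, is how far the number in this assay would move if an amine or a carboxylic acid took the place of the halogen, or if the shared core itself were changed.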